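From Sulfanyl to Sulfonyl at the Five-Membered Ring

The compounds below may be only part of what the source reports. "The series", "measured", "known", "first", "only" and "open" are said of these compounds alone.

Three compounds have so far been tested in a functional assay on MDA-MB-231 cells (Homo sapiens) for antiproliferative activity, read by MTT assay, with a stated time of 24 h; a lower number here means a stronger inhibitor, a higher number a weaker inhibitor:
Compound 1 `CCCCCSc1nnc(COc2cc(C)c3c(C)cc(=O)oc3c2)o1` gives > 100000 nM, a limit of the assay.
Compound 2 `Cc1cc(OCc2nnc(SCc3ccccc3)o2)cc2oc(=O)cc(C)c12` gives > 100000 nM, also a limit.
Compound 3 `Cc1cc(OCc2nnc(SCc3cccc(F)c3)o2)cc2oc(=O)cc(C)c12` gives > 100000 nM, again a limit.

Compound 3 therefore stands at the same limit as the other two, as the limit of > 100000 nM in this assay, at which 3 of the 3 values shown sit, records, and no number separates any of them. The three steps among them, a step that the two limits leave unreadable from compound 1 to compound 2, a step that the two limits leave unreadable from compound 1 to compound 3 and a step that the two limits leave unreadable from compound 2 to compound 3, cannot be read in size or direction for that reason.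

Compound 4 `Cc1cc(OCc2nnc(S(=O)(=O)Cc3ccccc3)o2)cc2oc(=O)cc(C)c12` is not yet measured. Its change from compound 3 is benzylsulfonyl in place of (3-fluorobenzyl)sulfanyl on an aromatic carbon. The step that comes closest in kind is a step that the two limits leave unreadable from compound 2 to compound 3, which touches the same benzyl arm, but it tells nothing of size; the other two steps, a step that the two limits leave unreadable from compound 1 to compound 2 and a step that the two limits leave unreadable from compound 1 to compound 3, are just as silent. With every measured value sitting at the limit, there is no footing for expecting compound 4 to move in either direction beyond the scatter.

Compound 4 is accordingly expected to give 100000 nM in this assay, within 30000 nM to 300000 nM, which corresponds to an expected step of a number no higher from compound 3 to compound 4 (the limit leaves the size open) from compound 3.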

Compound 4, half-maximal inhibitory concentration: 7070 nM
Compound 4: middle estimate off by 14-fold (1.15 log units), on the high side; measured number below the stated range.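

Going by these compounds alone, the sulfur at this aromatic carbon of the five-membered ring is the first place where a change can be read: with the benzyl arm kept, benzylsulfonyl in place of benzylsulfanyl gives an at least 14-fold lower number from compound 2 to compound 4 (1.15 log units; beyond the scatter) in this assay. The two wider exchanges at the same carbon point the same way, with benzylsulfonyl in place of (3-fluorobenzyl)sulfanyl giving an at least 14-fold lower number from compound 3 to compound 4 (1.15 log units; beyond the scatter) and benzylsulfonyl in place of pentylsulfanyl giving an at least 14-fold lower number from compound 1 to compound 4 (1.15 log units; beyond the scatter). The steps among compound 1, compound 2 and compound 3 still cannot be read, and compound 4 alone carries a number rather than a limit: the limit of > 100000 nM in this assay, at which 3 of the 4 values shown sit.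

From the compounds shown here alone, compound 4 has a plain benzyl arm, so it remains open whether a sulfonyl group would give a readable number with a pentyl or a 3-fluorobenzyl arm in this assay. Also open is how a sulfinyl group or a sulfonamide at this same carbon would read, since the compounds shown hold only the sulfanyl and sulfonyl forms.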